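This account rests on a few compounds, and the source may have more. Where it says the series, first, only, none or still open, it means among the compounds named here.

Compound 1 `O=S(=O)(c1cccc(F)c1)c1cn(C2CCNC2)c2ncccc12` — 278 nM
Compound 2 `CN1CCC(n2cc(S(=O)(=O)c3cccc(F)c3)c3cccnc32)C1` — 231 nM
Compound 3 `CN1CCCC(n2cc(S(=O)(=O)c3cccc(F)c3)c3cccnc32)C1` — 306 nM

In a functional assay on HeLa cells for agonist activity at 5-hydroxytryptamine receptor 6 (Homo sapiens), read by cAMP accumulation and immunoassay (a lower number here means that less compound is needed, a higher number that more compound is needed for the effect), compound 3 sits together with the other two inside the usual scatter: a 1.1-fold higher number from compound 1 to compound 3 (0.04 log units; within the scatter) and a 1.3-fold higher number from compound 2 to compound 3 (0.12 log units; within the scatter), so nothing separates the three numbers. Compound 4 `CCN1CCCC(n2cc(S(=O)(=O)c3cccc(F)c3)c3cccnc32)C1` differs from compound 3 by methyl in place of hydrogen on a saturated chain carbon bound to an amine nitrogen in a ring. For the measured compounds named here, two measured steps bear on this change. The closest is a 1.2-fold lower number from compound 1 to compound 2 (0.08 log units; within the scatter), where a methyl also enters on the amine nitrogen of the ring, with no movement beyond the scatter. The other is a 1.3-fold higher number from compound 2 to compound 3 (0.12 log units; within the scatter), where the ring that carries the amine is exchanged, again with no movement beyond the scatter. Both show that small changes around this amine nitrogen leave this assay essentially unchanged, so no step beyond the scatter is expected in either direction. Compound 4 is therefore expected to give 300 nM, with a range from 120 nM to 750 nM. This estimate means a step of a 1.0-fold lower number from compound 3 to compound 4 (0.01 log units; within the scatter), expected to fall within the scatter.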

Compound 4, half-maximal effective concentration: 60 nM
For compound 4 the middle estimate is 5.0-fold (0.70 log units) above the measured one; measured number below the stated range.
By their numbers in this assay, from the lowest: compound 4; then compounds 2, 1 and 3 (each within the scatter of the next).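

In this assay, for the compounds shown here, methyl in place of hydrogen on a saturated chain carbon bound to an amine nitrogen in a ring gives a 5.1-fold lower number from compound 3 to compound 4 (0.71 log units; beyond the scatter) and is the first step to pass beyond the scatter. Compound 4 also separates from both other compounds, with a 3.9-fold lower number from compound 2 to compound 4 (0.59 log units; beyond the scatter) and with a 4.6-fold lower number from compound 1 to compound 4 (0.67 log units; beyond the scatter) so the 1-ethylpiperidin-3-yl group stands apart, while pyrrolidin-3-yl, 1-methylpyrrolidin-3-yl and 1-methylpiperidin-3-yl did not separate from one another. No available evidence accounts for this step.

The compounds shown leave open whether a longer chain, such as propyl, or a branched one, such as isopropyl, in place of the ethyl would lower the number further or reverse the step. They also leave open whether ethyl on the pyrrolidine amine would give a similar step.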